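Hydroxyphenyl placement: three measured compounds, one pending

The source may report more compounds than this note shows. Statements on the series, on what has been measured and on what is new or still open speak of the compounds shown alone.

Measured so far:
Compound 1 `Oc1ccc(-c2cc(-c3ccc(F)cc3)cc(-c3ccccc3O)n2)cc1` in a functional assay on HeLa cells (Homo sapiens) for inhibition (on this read-out lower numbers stand for stronger inhibition and higher numbers for weaker inhibition), gives > 50000 nM, which is a limit of the assay.
Compound 2 `Oc1ccc(-c2cc(-c3ccc(F)cc3)cc(-c3cccc(O)c3)n2)cc1` gives 8080 nM.
Compound 3 `Oc1ccccc1-c1cc(-c2ccc(OC(F)(F)F)cc2)cc(-c2ccccc2O)n1` gives > 50000 nM, again a limit of the assay.

Two of the three values are the limit of > 50000 nM in this assay, at which 2 of the 3 values shown sit. Within the data shown here, the only counted step is 3-hydroxyphenyl in place of 2-hydroxyphenyl on an aromatic carbon, which produced an at least 6.1-fold lower number from compound 1 to compound 2 (0.79 log units; beyond the scatter). Compound 4 `Oc1cccc(-c2cc(-c3ccc(OC(F)(F)F)cc3)cc(-c3ccccc3O)n2)c1` arises from compound 3 by 3-hydroxyphenyl in place of 2-hydroxyphenyl on an aromatic carbon. The difference between the cores of compound 1 and compound 3 is not broken down here. The surroundings differ: in compound 1 the site is meta to a 4-fluorophenyl group and meta to a 4-hydroxyphenyl group, in compound 3 it is meta to a 2-hydroxyphenyl group and meta to a large group, so this is the same kind of change, not the same change. Resting on an at least 6.1-fold lower number from compound 1 to compound 2 (0.79 log units; beyond the scatter), the step of an at least 3.3-fold lower number from compound 3 to compound 4 (0.52 log units; beyond the scatter) is expected. For compound 4 the estimate in this assay is 15000 nM, between 5000 nM and 50000 nM.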

Compound 4, half-maximal inhibitory concentration: 20600 nM
The estimate for compound 4 lay 1.4-fold (0.14 log units) below the measured number; low and high end bracket the measured number.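

In this assay, 3-hydroxyphenyl in place of 2-hydroxyphenyl gives an at least 2.4-fold lower number from compound 3 to compound 4 (0.38 log units; beyond the scatter), so the direction of the change seen on the core of compound 1 also holds on the core of compound 3. Two cores show only that direction, and the size of the effect stays unsettled: the same change on two cores in this assay, an at least 6.1-fold lower number (0.79 log units; beyond the scatter) from compound 1 to compound 2 and an at least 2.4-fold lower number (0.38 log units; beyond the scatter) from compound 3 to compound 4; the limit leaves it open whether they differ Both steps start from a value that is a limit and not a number: the limit of > 50000 nM in this assay, at which 2 of the 4 values shown sit.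

The compounds shown leave open whether the remaining 2-hydroxyphenyl group of compound 4 would respond to the same change. They also leave open whether an amine or a carboxylic acid could take the place of the hydroxyl on the 3-hydroxyphenyl group and keep the lower number.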